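The compounds below may be only part of what the source reports. "The series", "measured", "known", "first", "only" and "open" are said of these compounds alone.

Compound 2 `Cc1ccc(CNC(=O)n2c(N)nc3ccccc32)cc1` belongs to a small set studied in an ADME assay on a cell-free system (plasma, Mus musculus) for metabolic stability, read by HPLC, with a stated time of 120 min, tested at 2 uM; on this read-out lower numbers stand for a shorter-lived compound and higher numbers for a longer-lived compound. In this assay compound 2 gives only a limit, < 0.0834 h. Compound 1 `Cc1ccccc1CNC(=O)n1c(N)nc2ccccc21` likewise gives only a limit in this assay, < 0.0834 h. Compound 3 `CCCCCCNC(=O)n1nnc2ccccc21`, built on a different core, gives in this assay 0.217 h. The one measured step among these, a step that the two limits leave unreadable from compound 1 to compound 2, cannot be sized because both of its compounds sit at the limit of < 0.0834 h in this assay, at which 2 of the 3 values shown sit.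

Compound 4 `Nc1nc2ccccc2n1C(=O)NCc1ccccc1` differs from compound 2 by hydrogen in place of methyl on an aromatic carbon. Among the measured compounds shown here, no measured step in this assay touches this change, so the set offers no direct guide to its size or direction; the only firm point is that compound 2 itself stands at the limit. On that basis the step that the limit leaves unreadable from compound 2 to compound 4 is expected to stay within the usual scatter, with compound 4 most likely again reported only as a limit. Compound 4 is therefore estimated at 0.06 h in this assay, within a range from 0.02 h to 0.2 h.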

Compound 4, half-life in the plasma assay: 0.217 h
Compound 4: middle estimate off by 3.6-fold (0.56 log units), on the low side; measured number outside the range, above it.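

Among the compounds shown here, in the plasma assay, taking the methyl off the ring gives the first readable steps, an at least 2.6-fold higher number from compound 2 to compound 4 (0.41 log units; beyond the scatter) and an at least 2.6-fold higher number from compound 1 to compound 4 (0.41 log units; beyond the scatter), so 4-methylphenyl and 2-methylphenyl both give way to phenyl with a rise beyond the scatter. These steps give only a minimum size because they start from a limit: the limit of < 0.0834 h in the plasma assay, at which 2 of the 4 values shown sit. In a physicochemical assay for metabolic stability, read by HPLC, at pH 4.5, tested at 10 uM (on this read-out higher numbers stand for a longer-lived compound and lower numbers for a shorter-lived compound), compound 2 gives 0.567 h and compound 4 gives 0.7 h, with a 1.2-fold higher number from compound 2 to compound 4 (0.09 log units; within the scatter), so the same change stays within the scatter on this read-out.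

Going by these compounds, the step between compound 1 and compound 2 still cannot be read, and the full size of the steps to compound 4 stays unknown. On these data alone, whether a chlorine or a methoxy group at that ring carbon would stand with methyl or with hydrogen also remains open.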